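Methyl for fluoro on a weak cyano nucleoside

The compounds below may be only part of what the source reports. "The series", "measured", "known", "first", "only" and "open" are said of these compounds alone.

Measured in a functional assay on HeLa cells (Homo sapiens); a lower number here means a stronger inhibitor, a higher number a weaker inhibitor:
Compound 1, `N#C[C@]1(O)[C@H](O)[C@@H](CO)O[C@@H](n2cc(F)c(O)nc2=O)[C@@H]1O`, gives 4500 nM.
Compound 2, `N#C[C@]1(O)[C@H](O)[C@@H](CO)O[C@@H](n2ccc(O)nc2=O)[C@@H]1O`, gives only a limit of the assay, > 500000 nM.
Compound 3, `N#C[C@H]1[C@@H](O)[C@H](n2cc(F)c(O)nc2=O)O[C@H](CO)[C@H]1O`, gives 819000 nM.

Of the two numbers shown, compound 3 stands highest, far above compound 1. Compound 4, `Cc1cn([C@@H]2O[C@H](CO)[C@@H](O)[C@@H](C#N)[C@H]2O)c(=O)nc1O`, differs from compound 3 by methyl in place of fluoro on an aromatic carbon. Among the compounds with values here, the one measured step at this carbon exchanged fluoro for hydrogen: an at least 110-fold higher number from compound 1 to compound 2 (2.04 log units; beyond the scatter). Compound 2 sits at the limit of > 500000 nM in this assay, at which 1 of the 3 values shown sits. Methyl is a different replacement from hydrogen, so that step bears only loosely here, though it points towards weaker inhibition. The expected step is therefore a 1.8-fold higher number from compound 3 to compound 4 (0.26 log units; within the scatter), towards a weaker inhibitor. Compound 4 is estimated at 1500000 nM in this assay, between 200000 nM and 10000000 nM.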

Compound 4, half-maximal inhibitory concentration: > 750000 nM
Compound 4: only a limit was reported (the forecaster's own chance of this, stated with the estimate: 50%); the middle value lies beyond the limit too.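

Compound 4 gives > 750000 nM which is only a limit of the assay, so the step from compound 3 to compound 4 cannot be read. As far as these compounds go, whether methyl in place of fluoro changes inhibition here stays open.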